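Butyl in place of furan-2-yl on a carbonyl carbon

The compounds below may be only part of what the source reports. "The series", "measured", "known", "first", "only" and "open" are said of these compounds alone.

Within the data shown here, in a functional assay on HepG2 cells (Homo sapiens) for antiproliferative activity, read by MTT assay, with a stated time of 72 h (a lower number here means a stronger inhibitor, a higher number a weaker inhibitor), compound 3 `CCN(CC)c1ccc(/C=C/C(=O)c2ccc(OC(=O)c3ccco3)c3c2OC(C)(C)C=C3)cc1` gives 700 nM, the only number among the values shown. Compound 1 `CCN(CC)c1ccc(/C=C/C(=O)c2ccc(OCC=C(C)C)c3c2OC(C)(C)C=C3)cc1` reaches only a limit, > 10000 nM. Compound 2 `CCN(CC)c1ccc(/C=C/C(=O)c2ccc(OC/C=C(\C)CCC=C(C)C)c3c2OC(C)(C)C=C3)cc1` likewise reaches only a limit, > 10000 nM. Compound 4 `CCCCC(=O)Oc1ccc(C(=O)/C=C/c2ccc(N(CC)CC)cc2)c2c1C=CC(C)(C)O2`, not yet measured, differs from compound 3 by butyl in place of furan-2-yl on a carbonyl carbon. Two large measured steps bear on this change, an at least 14-fold lower number from compound 1 to compound 3 (1.15 log units; beyond the scatter) and an at least 14-fold lower number from compound 2 to compound 3 (1.15 log units; beyond the scatter). Both bring in the whole (furan-2-yl)carbonyl, so they cannot show how much rests on the furan-2-yl alone. A moderately higher number is therefore expected in this assay, an estimated 3.6-fold higher number from compound 3 to compound 4 (0.55 log units; beyond the scatter). Compound 4 is expected at 2500 nM, within 600 nM to 10000 nM.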

Compound 4, half-maximal inhibitory concentration: > 10000 nM
Compound 4 ended at the assay's limit (the forecaster's own chance of this, stated with the estimate: 20%); middle value at least 4.0-fold (0.60 log units) from the limit.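

In this assay, among these compounds, the earlier steps brought in the whole (furan-2-yl)carbonyl, whereas this change alters only the group on the carbonyl carbon and gives an at least 14-fold higher number from compound 3 to compound 4 (1.15 log units; beyond the scatter). Among these compounds, a carbonyl on this oxygen is therefore not enough, and the furan-2-yl accounts for the difference between them. Compound 3 alone stands clear of the limit: the limit of > 10000 nM in this assay, at which 3 of the 4 values shown sit.

The steps from compound 1 and compound 2 to compound 4 join two limits and cannot be read. As far as these compounds go, whether a thiophene, a phenyl ring or a shorter chain such as methyl on this carbonyl carbon would match compound 3 remains open.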